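This account rests on a few compounds, and the source may have more. Where it says the series, first, only, none or still open, it means among the compounds named here.

Measured in a functional assay on A549 cells (Homo sapiens) for inhibition, read by MTT assay, with a stated time of 48 h; a lower number here means a stronger inhibitor, a higher number a weaker inhibitor:
Compound 1 `Cn1c(/C=C2\SC(=O)N(CC(=O)Nc3cc(C(C)(C)C)on3)C2=O)nc2ccccc21`: 15300 nM
Compound 2 `CCn1c(/C=C2\SC(=O)N(CC(=O)N3CCCCC3)C2=O)nc2ccccc21`: > 50000 nM (a limit, not a number)
Compound 3 `Cn1c(/C=C2\SC(=O)N(CC(=O)N3CCCCC3)C2=O)nc2ccccc21`: > 50000 nM (a limit, not a number)

Compound 2 has no number of its own, only the limit > 50000 nM. Compound 2 sits at the limit of > 50000 nM in this assay, at which 2 of the 3 values shown sit.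

Compound 4 `CCn1c(/C=C2\SC(=O)N(CC(=O)N3CCCC3)C2=O)nc2ccccc21` is compound 2 with a single change, pyrrolidin-1-yl in place of piperidin-1-yl on a carbonyl carbon. The six-membered non-aromatic ring becomes a five-membered one.

Among the compounds with values here, two measured steps bear on this. On that same carbonyl carbon, piperidin-1-yl in place of (5-(tert-butyl)-1,2-oxazol-3-yl)amino gave an at least 3.2-fold higher number from compound 1 to compound 3 (0.51 log units; beyond the scatter). Elsewhere on the molecule, hydrogen in place of methyl on a saturated chain carbon bound to an aromatic nitrogen gave a step that the two limits leave unreadable from compound 2 to compound 3. Neither step exchanges one of these two rings for the other, and neither gives a size for this change.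

No step beyond the scatter is expected in this assay, and another limit is the most likely report. The estimate means a step that the limit leaves unreadable from compound 2 to compound 4, which is an expected step and not a measured one. For compound 4 the estimated value is 60000 nM, with an expected range from 25000 nM to 120000 nM.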

Compound 4, half-maximal inhibitory concentration: 31200 nM
Compound 4: the middle estimate sits 1.9-fold (0.28 log units) above what was measured; low and high end bracket the measured number.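

Within the data shown here, with compound 4, a saturated ring on this carbonyl carbon gives a readable number for the first time in this assay, whereas the two piperidin-1-yl compounds reached only a limit. Shrinking the six-membered ring to the five-membered one gives an at least 1.6-fold lower number from compound 2 to compound 4 (0.20 log units; that floor lies within the scatter), and this figure is only a floor, so the real gap could be larger or could stay within the usual scatter of this assay. Compound 2 carries a limit and not a number, so the step has a smallest possible size but no upper end: the limit of > 50000 nM in this assay, at which 2 of the 4 values shown sit.

As far as these compounds go, it remains open how other groups would read on this carbonyl carbon, such as the four-membered azetidin-1-yl ring, the oxygen-containing morpholin-4-yl ring or an open-chain diethylamino group, and so whether ring size itself matters here. Among these compounds, also open is whether the methyl and ethyl groups on the aromatic nitrogen differ once pyrrolidin-1-yl is in place, since the only pair that compares them sits at the limit and cannot be read.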